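Working notes: from compound 2 to compound 3

The source may hold more compounds than are shown below. What is called first, only, known or untested is meant among the compounds shown, and "the series" means these compounds.

Measured in a functional assay on ileum (Cavia porcellus) for antagonist activity; on this read-out lower numbers stand for stronger inhibition and higher numbers for weaker inhibition:
- compound 1 `CCc1cc2c(O)c([N+](=O)[O-])c(=O)oc2cc1OCCCOc1ccccc1`: > 10000 nM (a limit)
- compound 2 `COc1ccc(OCCCOc2ccc3c(O)c([N+](=O)[O-])c(=O)oc3c2)cc1`: > 4000 nM (a limit)

Compound 2 stands at > 4000 nM in this assay, and this is a limit, not a number. Compound 1 gives > 10000 nM, which is also a limit. Among the measured compounds shown here, the series therefore offers no measured step, and the two compounds cannot be ranked against each other.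

Compound 3 `Cc1cccc(OCCCOc2ccc3c(O)c([N+](=O)[O-])c(=O)oc3c2)c1` differs from compound 2 in one place: 3-methylphenyl in place of 4-methoxyphenyl on an oxygen on a saturated carbon. There, 3-methylphenyl stands in place of 4-methoxyphenyl on an oxygen on a saturated carbon. For the measured compounds named here, no measured step gives a size for this change. No step beyond the scatter is expected in this assay, and weak inhibition is expected to persist, possibly with only a limit reported again. This expectation rests on compound 2, whose > 4000 nM is a limit. The estimated step is a step that the limit leaves unreadable from compound 2 to compound 3. For compound 3 the estimated value is 6000 nM, with an expected range of 1500 nM to 20000 nM.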

Compound 3, half-maximal inhibitory concentration: 4400 nM
Compound 3: the middle estimate sits 1.4-fold (0.13 log units) above what was measured, within the range that was stated.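

Compound 2 stands at > 4000 nM in this assay, which is a limit and not a number. Among the compounds shown here, compound 3 gives 4400 nM, but no step from compound 2 to compound 3 can be read. The compounds shown leave open what size of change, if any, goes with 3-methylphenyl in place of 4-methoxyphenyl in this assay.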